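This account rests on a few compounds, and the source may have more. Where it says the series, first, only, none or still open, it means among the compounds named here.

Working notes on the series. For the measured compounds named here, compound 3 `O=C(O)CCC(=O)N(C1CC1)[C@H]1c2ccccc2N(C(=O)c2ccc(F)cc2)[C@H]2CC[C@H]21` gives 14 uL/min in an ADME assay on cells (Hepatocyte, Rattus norvegicus) for metabolic stability (a lower number here means slower removal, a higher number faster removal of the compound), the lowest of the three numbers so far, though its two neighbours sit within the scatter of it: compound 1 `O=C(O)CCC(=O)N(C1CC1)[C@H]1c2ccccc2N(C(=O)c2cccc(OC(F)(F)F)c2)[C@H]2CC[C@H]21` gives 15 uL/min and compound 2 `O=C(O)COC(=O)N(C1CC1)[C@H]1c2ccccc2N(C(=O)c2cccc(F)c2)[C@H]2CC[C@H]21` gives 20 uL/min. Going by the values given here, the one single-point step measured, a 1.1-fold lower number from compound 1 to compound 3 (0.03 log units; within the scatter), shows that the aryl change left the read-out essentially unmoved.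

Compound 4 `O=C(O)COC(=O)N(C1CC1)[C@H]1c2ccccc2N(C(=O)c2ccc(F)cc2)[C@H]2CC[C@H]21` is the next compound to be measured. Relative to compound 3 it carries carboxymethoxy in place of 2-carboxyethyl on a carbonyl carbon. Among the compounds with values here, no measured step isolates this change: compound 2 carries the same carboxymethoxycarbonyl group but differs from compound 3 in two places, so its value only shows that a compound with this group can sit near compound 3 and compound 1. Given that, and since the one measured step of a 1.1-fold lower number from compound 1 to compound 3 (0.03 log units; within the scatter) was flat, the step from compound 3 to compound 4 is expected to be small, a 1.3-fold higher number from compound 3 to compound 4 (0.11 log units; within the scatter), within the scatter. Compound 4 is accordingly estimated at 18 uL/min in this assay, with a range from 9 uL/min to 34 uL/min.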

Compound 4, intrinsic clearance in a liver preparation (reported as CLH), per the amount of preparation that the assay uses: 13 uL/min
Estimate against measurement, compound 4: 1.4-fold (0.14 log units) above; the range from low to high includes it.
By their numbers in this assay, from the lowest: compounds 4, 3, 1 and 2 (each within the scatter of the next).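

In this assay, for the compounds shown here, the step of a 1.1-fold lower number from compound 3 to compound 4 (0.03 log units; within the scatter) gives the first isolated reading of carboxymethoxy in place of 2-carboxyethyl on this carbonyl carbon, and the swap leaves the read-out essentially unmoved. The fluorine shift on the other carbonyl group, 4-fluorophenyl in place of 3-fluorophenyl, now has its own reading too, a 1.5-fold lower number from compound 2 to compound 4 (0.19 log units; within the scatter), and it is likewise flat, as is the earlier aryl step. Across these four compounds, neither place has moved the number beyond the scatter, and nothing measured here accounts for that flatness.

All four compounds end the chain in a carboxylic acid, so an amide or an ester in its place, or a longer chain, remains unread. Going by these compounds, how an amine on the aryl ring would read in this assay also stays open.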